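Swapping chlorines for fluorines on a chalcone-like aryl ketone

This account rests on a few compounds, and the source may have more. Where it says the series, first, only, none or still open, it means among the compounds named here.

Of the compounds shown here, two sharing one core have been tested in a functional assay on NCI-H460 cells (Homo sapiens) for inhibition, read by sulforhodamine B assay, with a stated time of 48 h; a higher number here means a weaker inhibitor of growth, a lower number a stronger inhibitor of growth. Compound 1 `COc1ccc(-c2cc(/C=C/C(=O)c3ccc(N)cc3)[nH]n2)cc1` gives 2070 nM. Compound 2 `COc1cc(-c2cc(/C=C/C(=O)c3ccc(Cl)c(Cl)c3)[nH]n2)cc(OC)c1OC` gives 4900 nM, the higher of the two numbers, with compound 1 the lower one and the gap between them beyond the usual scatter. Compound 3 `COc1cc(-c2cc(/C=C/C(=O)c3ccc(F)c(F)c3)[nH]n2)cc(OC)c1OC` differs from compound 2 only by 3,4-difluorophenyl in place of 3,4-dichlorophenyl on a carbonyl carbon. Among the measured compounds shown here, no measured pair shows what such a change does here, so the expected step of a 1.1-fold higher number from compound 2 to compound 3 (0.05 log units; within the scatter) is small, in no sure direction, and may stay within the scatter. Compound 3 is therefore estimated at 5500 nM, between 2000 nM and 15000 nM.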

Compound 3, concentration for 50% growth inhibition: 2960 nM
Beside the measured number, compound 3's estimate is 1.9-fold (0.27 log units) above it; low and high end bracket the measured number.
By their numbers in this assay, from the lowest: compounds 1, 3 and 2 (each within the scatter of the next, the first and the last beyond it).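

In this assay, putting 3,4-difluorophenyl in place of 3,4-dichlorophenyl on the carbonyl carbon gives a 1.7-fold lower number from compound 2 to compound 3 (0.22 log units; within the scatter). This first single-place comparison therefore does not separate the two halogen pairs at this position. Nothing measured here bears on why the two compounds fall so close together.

Compound 1 differs from both compounds in more than one place, so it cannot be set against this change. From the compounds shown here alone, whether a phenyl carrying a nitrile or a trifluoromethyl group on the same carbonyl carbon would move the number beyond the scatter remains open.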